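Anilide series: second methoxy on the aniline ring

The source may report more compounds than this note shows. Statements on the series, on what has been measured and on what is new or still open speak of the compounds shown alone.

Measured so far in an in vitro assay on BTI-TN-5B1-4 cells for inhibition of Amine oxidase [flavin-containing] B (Homo sapiens), read by fluorescence; a lower number here means a stronger inhibitor, a higher number a weaker inhibitor:
compound 1 `O=C(Nc1ccccc1)c1cc2ccccc2oc1=O`: 760 nM
compound 2 `CC(C)c1ccc(NC(=O)c2cc3ccccc3oc2=O)cc1`: 650 nM
compound 3 `COc1ccc(NC(=O)c2cc3ccccc3oc2=O)cc1`: 820 nM

Compound 3 carries the highest of the three numbers, but the steps of a 1.1-fold higher number from compound 1 to compound 3 (0.03 log units; within the scatter) and a 1.3-fold higher number from compound 2 to compound 3 (0.10 log units; within the scatter) both lie within the scatter, so no order among the three compounds is established; the shared core of compound 1 tolerates the substituents tried so far without a measurable shift.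

Compound 4 `COc1ccc(NC(=O)c2cc3ccccc3oc2=O)cc1OC` differs from compound 3 by methoxy in place of hydrogen on an aromatic carbon. The measured steps that bear on this are the single substitutions on the same aromatic ring: a 1.2-fold lower number from compound 1 to compound 2 (0.07 log units; within the scatter), a 1.1-fold higher number from compound 1 to compound 3 (0.03 log units; within the scatter) and a 1.3-fold higher number from compound 2 to compound 3 (0.10 log units; within the scatter), none of them beyond the scatter. Since each of these changes left the number in place, a further methoxy on an aromatic carbon is expected to do the same, giving a 1.0-fold higher number from compound 3 to compound 4 (0.02 log units; within the scatter). Compound 4 is therefore estimated at 850 nM, with a range from 400 nM to 1800 nM. Among the measured compounds shown here, no measured step places a second group on that ring, so the range is kept wide.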

Compound 4, half-maximal inhibitory concentration: 860 nM
Compound 4: the middle estimate sits 1.0-fold (0.01 log units) below what was measured; low and high end bracket the measured number.
By their numbers in this assay, from the lowest: compounds 2, 1, 3 and 4 (each within the scatter of the next).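

In this assay, adding a methoxy ortho to a methoxy group and meta to a large group gives a 1.0-fold higher number from compound 3 to compound 4 (0.02 log units; within the scatter) and so no measurable shift. Compound 4 is the first shown with two groups on this six-membered aromatic ring, so the ring's tolerance now extends beyond the single substitutions of compound 2 and compound 3 to this second group. No evidence bears on why the number holds here.

On these data alone, it remains open whether any group on this ring can move the number beyond the scatter, for instance an amine, a carboxylic acid or a longer chain at this same place. Also open is whether replacing the amide hydrogen or altering the shared core would shift the number, as every step shown lies on this one ring.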